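A few compounds are considered here, and "the series" means these few. Any claim that something is new, unique, unknown or untested is made for them only; others in the source may bear on it.

Working notes on the series.

Of the compounds shown here, three carry numbers so far. Compound 1 `O=C(Nc1cc(C(F)(F)F)cc(C(F)(F)F)c1)c1ccc(Cl)cc1O` gives 850 nM in a functional assay on NALM-6 cells (Homo sapiens) for cytotoxicity, read by luminescence and CellTiter-Glo, with a stated time of 3 days; a higher number here means a weaker inhibitor, a lower number a stronger inhibitor. Compound 3 `O=C(Nc1cc(Cl)cc(Cl)c1)c1cc(F)ccc1O` gives 1440 nM in this assay. Compound 2 `N#Cc1ccc(NC(=O)c2ccc3cccnc3c2O)c(Cl)c1` gives 420 nM in this assay and holds the lowest number of the three; its gap to compound 1 and its gap to compound 3 both lie beyond the usual scatter, so compound 2 is the strongest inhibitor among the measured set. The three compounds differ from one another in more than one place, so none of these gaps can be tied to a single change.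

Compound 4 `N#Cc1ccc(NC(=O)c2ccc3cccnc3c2O)c(C#N)c1` has not been measured. It differs from compound 2 by cyano in place of chloro on an aromatic carbon. For the measured compounds named here, no measured pair shows this change on its own, so nothing in the data fixes its size or direction. The working expectation is a modest step, close to or within the scatter, and the expected step is a 1.2-fold higher number from compound 2 to compound 4 (0.08 log units; within the scatter). On that basis compound 4 is estimated at 500 nM in this assay, with an expected range from 200 nM to 1300 nM; a result anywhere in that range would leave compound 4 near compound 2.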

Compound 4, half-maximal inhibitory concentration: 350 nM
The estimate for compound 4 lay 1.4-fold (0.15 log units) above the measured number; low and high end bracket the measured number.
By their numbers in this assay, from the lowest: compounds 4 and 2 (each within the scatter of the next); then compounds 1 and 3 (each within the scatter of the next).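

For the compounds shown here, the swap of chloro for cyano, on an aromatic carbon ortho to a large group and meta to a cyano group, is the first change that can be read on its own: in this assay the step is a 1.2-fold lower number from compound 2 to compound 4 (0.08 log units; within the scatter) and so leaves the two compounds indistinguishable. At this one place, then, the series accepts cyano with its 2 heavy atoms, its triple bond and its hydrogen-bond acceptor in place of the single chlorine atom, with no separation in the read-out on the core shared by these two compounds. Nothing available explains why the two compounds read alike.

What the compounds shown leave open is whether this place is equally undemanding for groups of another kind, such as an amine, a carboxylic acid, a methoxy group or a bare hydrogen, since chloro and cyano are the only two groups compared here. Also open, from the compounds shown here alone, is whether the same swap would give a similar step on the cores of compound 1 and compound 3, as this single pair speaks only for its own core.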